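From 2-chlorophenyl to 3-chlorophenyl: a step at the limit

This account rests on a few compounds, and the source may have more. Where it says the series, first, only, none or still open, it means among the compounds named here.

Compounds measured so far in a functional assay on NCI-H460 cells (Homo sapiens) for cytotoxicity, read by sulforhodamine B assay; a lower number here means that less compound is tolerated, a higher number that more compound is tolerated (both values are limits)
- Compound 1 `CC1=CC[C@@H]([C@@](C)(O)CCCC(C)(C)NC(=S)N/N=C\c2ccc(O)cc2)CC1` gives > 100000 nM as a limit
- Compound 2 `CC1=CC[C@@H]([C@@](C)(O)CCCC(C)(C)NC(=S)N/N=C\c2ccccc2Cl)CC1` gives > 100000 nM as a limit

Compound 2 has no exact number in this assay and stands only at the limit > 100000 nM in this test. Among the measured compounds shown here, the whole series so far is described by the limit of > 100000 nM in this assay, at which 2 of the 2 values shown sit, and holds no measured number.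

The next compound is compound 3 `CC1=CC[C@@H]([C@@](C)(O)CCCC(C)(C)NC(=S)N/N=C\c2cccc(Cl)c2)CC1` and the change is small: 3-chlorophenyl in place of 2-chlorophenyl on a carbon with a double bond to nitrogen gives 3-chlorophenyl in place of 2-chlorophenyl on a carbon with a double bond to nitrogen. For the measured compounds named here, the one measured step that bears on this place is a step that the two limits leave unreadable from compound 1 to compound 2 and it supplies no size to carry over. Compound 2 gives the limit > 100000 nM and this is the only anchor for the expectation. No shift beyond the scatter is therefore expected in this assay and a further limit is the likeliest report. The expected size is a number no higher from compound 2 to compound 3 (the limit leaves the size open) and nothing larger. For compound 3 the estimated value is 100000 nM (expected range 40000 nM to 200000 nM).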

Compound 3, concentration lethal to 50% of the cells: > 100000 nM
Compound 3: only a limit was reported; the forecaster's own chance of this, stated with the estimate: 80%; the middle value sits exactly at the limit.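

Among the compounds shown here, compound 1, compound 2 and compound 3 all stand at the same limit in this assay, so no step among them can be read. The series rests on a single limit: the limit of > 100000 nM in this assay, at which 3 of the 3 values shown sit.

The compounds shown leave open whether exchanging the 4-hydroxyphenyl, 2-chlorophenyl and 3-chlorophenyl groups changes the lethal concentration at all.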